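Swapping the ether substituent on a shared core

The source may hold more compounds than are shown below. What is called first, only, known or untested is meant among the compounds shown, and "the series" means these compounds.

Compound 1 `CCCCCCCCOC1CC(=O)Nc2c1c(C)nn2-c1ncnc2nc[nH]c12` gives 388 nM in a functional assay on HEK293 cells for agonist activity at G-protein coupled receptor 39 (Homo sapiens), read by scintillation proximity assay and inositol phosphate accumulation, with a stated time of 75 min; a higher number here means that more compound is needed for the effect, a lower number that less compound is needed.
Compound 2 `Cc1nn(-c2ncnc3nc[nH]c23)c2c1C(OCc1ccccc1C#N)CC(=O)N2` gives 127 nM in this assay.

Among the compounds with values here, compound 2 has the lowest number of the two measured compounds in this assay; the only other measured compound, compound 1, lies a 3.1-fold lower number from compound 1 to compound 2 (0.49 log units; beyond the scatter) away, a modest step that came from putting 2-cyanophenyl in place of heptyl on a saturated chain carbon bound to an oxygen on a saturated carbon.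

Compound 3 `Cc1nn(-c2ncnc3nc[nH]c23)c2c1C(OCc1ccc(C(C)C)cc1)CC(=O)N2` is the next one to be tested. Its difference from compound 2 is 4-isopropylphenyl in place of 2-cyanophenyl on a saturated chain carbon bound to an oxygen on a saturated carbon. Within the data shown here, no measured step covers this kind of exchange; the one step known, from compound 1 to compound 2, only says that an aromatic ring in this position was tolerated and somewhat helpful. Compound 3 is therefore expected to stay in the same broad region as compound 2, with a step of a 2.0-fold higher number from compound 2 to compound 3 (0.29 log units; within the scatter) in this assay. The estimate for compound 3 is 250 nM, within a range from 60 nM to 1000 nM.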

Compound 3, half-maximal effective concentration: 1690 nM
The estimate for compound 3 lay 6.8-fold (0.83 log units) below the measured number; measured number above the stated range.
By their numbers in this assay, from the lowest: compound 2; then compound 1; then compound 3.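

The exchange of 2-cyanophenyl for 4-isopropylphenyl gives a 13-fold higher number from compound 2 to compound 3 (1.12 log units; beyond the scatter) in this assay, although both groups hold one six-membered aromatic ring of carbon only, so the presence of such a ring does not by itself set the number at this position. What is attached to the ring matters here, and the outcome can go either way against the heptyl chain of compound 1: putting 4-isopropylphenyl in place of heptyl gives a 4.4-fold higher number from compound 1 to compound 3 (0.64 log units; beyond the scatter) in this assay, the opposite direction to the step from compound 1 to compound 2. Nothing available explains why these two groups differ so much.

The compounds shown do not separate the loss of the nitrile from the arrival of the isopropyl group, as the two groups also differ in where they sit on the ring. Going by these compounds, how a plain benzyl group or a 4-cyanobenzyl group would stand at this place remains open.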